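A few compounds are considered here, and "the series" means these few. Any claim that something is new, unique, unknown or untested is made for them only; others in the source may bear on it.

Compound 1 `CCc1oc([C@H](C)/C=C(\C)[C@H](OC(C)=O)[C@H](C)[C@@H](OC(=O)CC(C)C)[C@@H](C)c2oc([C@@H](C)[C@@H](O)CC)c(C)c(=O)c2C)c(C)c(=O)c1C`, tested in a functional assay on PC-3 cells (Homo sapiens) for inhibition, read by MTT assay, with a stated time of 72 h; a lower number here means a stronger inhibitor, a higher number a weaker inhibitor: compound 1 gives 3000 nM.
Compound 2 `CCc1oc([C@H](C)/C=C(\C)[C@H](OC(C)=O)[C@H](C)[C@@H](OC(=O)CC(C)C)[C@@H](C)c2oc([C@@H](C)[C@H](CC)OC(C)=O)c(C)c(=O)c2C)c(C)c(=O)c1C`: compound 2 gives 7000 nM.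
Compound 3 `CCC(=O)[C@H](C)c1oc([C@H](C)[C@@H]2O[C@](O)([C@@H](C)c3oc(CC)c(C)c(=O)c3C)[C@@H](C)[C@@H](OC(=O)CC(C)C)[C@@H]2C)c(C)c(=O)c1C`: compound 3 gives 16000 nM.

Compound 1 has the lowest number of the three, so it is the strongest inhibitor of this small set; compound 2 is the nearest to it and compound 3 the furthest, and both of those differences lie beyond the usual scatter. Among the measured compounds shown here, compound 3 has no single-point step to any other compound, so only its value and that of compound 1 can be set side by side.

Compound 4 `CCc1oc([C@H](C)/C=C(\C)[C@H](O)[C@H](C)[C@@H](OC(=O)CC(C)C)[C@@H](C)c2oc([C@@H](C)[C@@H](O)CC)c(C)c(=O)c2C)c(C)c(=O)c1C` differs from compound 1 by one change: hydrogen in place of acetyl on an oxygen on a saturated carbon. For the measured compounds named here, one measured step bears on this. The step of a 2.3-fold higher number from compound 1 to compound 2 (0.37 log units; beyond the scatter) added an acetyl at an oxygen on a saturated carbon, and the number rose modestly. The change to compound 4 runs the other way, removing an acetyl, though at a different oxygen of the shared core, so the earlier step is only a loose guide.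

On that basis a small step toward a lower number, or none beyond the scatter, is expected, about a 1.5-fold lower number from compound 1 to compound 4 (0.18 log units; within the scatter). Compound 4 is estimated to give 2000 nM, with a range of 800 nM to 5000 nM.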

Compound 4, half-maximal inhibitory concentration: > 100000 nM
Compound 4 was reported as a limit; the forecaster's own chance of this, stated with the estimate: 5%; at least 50-fold (1.69 log units) between middle value and limit.
By their numbers in this assay, from the lowest: compound 1; then compound 2; then compound 3. At a limit, above all of these: compound 4.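

In this assay, going from acetoxy to hydroxy at this oxygen on a saturated carbon is an at least 33-fold higher number from compound 1 to compound 4 (1.52 log units; beyond the scatter), so keeping the acetyl here matters far more than the opening comparison suggested. The earlier step, a 2.3-fold higher number from compound 1 to compound 2 (0.37 log units; beyond the scatter), placed an acetyl on a different oxygen of the shared core and moved the number only modestly, which shows that the two oxygens do not respond alike and that an acetyl change at one says little about the other. Compound 4 gives > 100000 nM, which is a limit and not a number, so the step printed here marks only how large the change is at the least: the limit of > 100000 nM in this assay, at which 1 of the 4 values shown sits.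

The compounds shown leave open whether this position needs an acetyl specifically or simply anything other than a free hydroxy. A propanoyl ester, a methyl ether or an amine at this oxygen-bearing carbon would help separate those two readings, and only such compounds could show how much of the change belongs to the acetyl itself.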